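This account rests on a few compounds, and the source may have more. Where it says the series, first, only, none or still open, it means among the compounds named here.

Three esters on the shared core have numbers in an assay on isolated protein for inhibition of Rho-associated protein kinase 2 (Homo sapiens), read by radiometric assay; a higher number here means a weaker inhibitor, a lower number a stronger inhibitor. Compound 1 `NCc1ccc(C(=O)Nc2ccncc2F)cc1-c1cccc(C(=O)OCC2CC2)c1` gives 2.7 nM. Compound 2 `NCc1ccc(C(=O)Nc2ccncc2F)cc1-c1cccc(C(=O)OCCO)c1` gives 1.4 nM. Compound 3 `COC(=O)c1cccc(-c2cc(C(=O)Nc3ccncc3F)ccc2CN)c1` gives 7.8 nM, the highest number of the three; its nearest neighbour is compound 1, separated by a 2.9-fold higher number from compound 1 to compound 3 (0.46 log units; beyond the scatter), and compound 2 stands furthest, separated by a 5.6-fold higher number from compound 2 to compound 3 (0.75 log units; beyond the scatter). The step of a 1.9-fold lower number from compound 1 to compound 2 (0.29 log units; within the scatter) lies within the scatter.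

Compound 4 `NCc1ccc(C(=O)Nc2ccncc2F)cc1-c1cccc(C(=O)OCC2CCCC2)c1` is not yet measured. It differs from compound 3 by cyclopentyl in place of hydrogen on a saturated chain carbon bound to an oxygen next to a carbonyl group; methoxycarbonyl becomes cyclopentylmethoxycarbonyl. The step bearing on it most directly is the one in the opposite direction, hydrogen in place of cyclopropyl, which read a 2.9-fold higher number from compound 1 to compound 3 (0.46 log units; beyond the scatter); hydroxymethyl in place of hydrogen at the same chain carbon read a 5.6-fold higher number from compound 2 to compound 3 (0.75 log units; beyond the scatter), again in the other direction. Going by the values given here, both substituents on this carbon gave lower numbers than the bare methyl ester, so for compound 4 a modest step towards a lower number is expected, about a 2.6-fold lower number from compound 3 to compound 4 (0.41 log units; beyond the scatter) in this assay, while noting that a cyclopentyl ring has no measured counterpart. Compound 4 is therefore estimated at 3 nM, with a range from 1.2 nM to 8 nM.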

Compound 4, half-maximal inhibitory concentration: 13 nM
For compound 4 the middle estimate is 4.3-fold (0.64 log units) below the measured one, and the stated range ends below it.
By their numbers in this assay, from the lowest: compounds 2 and 1 (each within the scatter of the next); then compounds 3 and 4 (each within the scatter of the next).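

In this assay cyclopentyl on the saturated chain carbon bound to an oxygen next to a carbonyl group cannot be told apart from hydrogen at that carbon (a 1.7-fold higher number from compound 3 to compound 4 (0.22 log units; within the scatter)), so compound 4 goes against the earlier reading that a substituent there lowers the number. Going by these compounds alone, a ring on this carbon is not enough on its own: the two rings do not read alike (a 4.8-fold higher number from compound 1 to compound 4 (0.68 log units; beyond the scatter)), and the widest step so far now stands against the hydroxymethyl ester (a 9.3-fold higher number from compound 2 to compound 4 (0.97 log units; beyond the scatter)), while compound 1 and compound 2 remain within the scatter of each other. No measurement at hand gives a reason for the gap between the cyclopropyl and cyclopentyl esters.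

Cyclobutyl on the same carbon would show whether the number climbs gradually from cyclopropyl to cyclopentyl or jumps at one ring, and an open chain such as isopropyl would show whether the ring itself matters. Methoxymethyl or aminomethyl in place of hydroxymethyl would show whether the free hydroxyl is needed for the low number of compound 2.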